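The source may hold more compounds than are shown below. What is called first, only, known or untested is meant among the compounds shown, and "the series" means these compounds.

In a functional assay on MDA-MB-231 cells (Homo sapiens) for inhibition, read by MTT assay, with a stated time of 96 h (on this read-out higher numbers stand for weaker inhibition of growth and lower numbers for stronger inhibition of growth), compound 3 `C=CCOC(=O)SCCCCCCNC(=O)c1cc(-c2ccncc2)n[nH]1` gives 36000 nM and compound 1 `O=C(NCCCCCCSSCCCCCCNC(=O)c1cc(-c2ccncc2)n[nH]1)c1cc(-c2ccncc2)n[nH]1` gives 27300 nM, two numbers within the scatter of each other. Compound 2 `CC(C)C(=O)SCCCCCCNC(=O)c1cc(-c2ccncc2)n[nH]1` reads > 50000 nM, which is a limit of this assay and not a number. Compound 4 `CCC(=O)SCCCCCCNC(=O)c1cc(-c2ccncc2)n[nH]1` differs from compound 3 by ethyl in place of allyloxy on a carbonyl carbon, with ethyl in place of allyloxy on a carbonyl carbon. Among the measured compounds shown here, the only measured step at this place is an at least 1.3-fold lower number from compound 2 to compound 3 (0.14 log units; that floor lies within the scatter), with allyloxy in place of isopropyl, and it is bounded on one side only. Compound 4 also lacks the allyloxy, so any drift is expected toward a higher number. The estimated change is a 1.3-fold higher number from compound 3 to compound 4 (0.10 log units; within the scatter), which is expected to stay within the scatter. For compound 4 the estimated value is 45000 nM, with an expected range from 25000 nM to 90000 nM.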

Compound 4, concentration for 50% growth inhibition: > 50000 nM
Compound 4: only a limit was reported; the forecaster's own chance of this, stated with the estimate: 45%; at least 1.1-fold (0.04 log units) between middle value and limit.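

With ethyl in place of allyloxy on a carbonyl carbon, compound 4 stands at a limit of the assay and not at a number. In this assay this gives an at least 1.3-fold higher number from compound 3 to compound 4 (0.14 log units; that floor lies within the scatter), so even this second change at the position shows no step beyond the scatter. The step from compound 2 to compound 4 cannot be read, since the values of both are limits: the limit of > 50000 nM in this assay, at which 2 of the 4 values shown sit. On these data alone, whether an amine or a carboxylic acid in place of the ethyl would bring a number clear of that limit stays open. So does whether a longer chain would.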